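A few compounds are considered here, and "the series" means these few. Any claim that something is new, unique, unknown or untested is made for them only; others in the source may bear on it.

Measured so far in a functional assay on SiHa cells (Homo sapiens) for inhibition; on this read-out higher numbers stand for weaker inhibition and lower numbers for stronger inhibition
- compound 1 `COc1cc(/C=C/C(=O)c2cccc(NC(=O)c3c(Cl)cccc3Cl)c2)ccc1O` gives 3.56 ug/mL
- compound 2 `COc1cc(/C=C/C(=O)c2cccc(NC(=O)c3cc(Cl)cc(Cl)c3)c2)ccc1O` gives 17.7 ug/mL
- compound 3 `COc1cc(/C=C/C(=O)c2cccc(NC(=O)c3ccco3)c2)ccc1O` gives 0.76 ug/mL

Compound 3 has the lowest of the three numbers, and its steps to both others lie beyond the scatter. The open case is compound 4 `COc1cc(/C=C/C(=O)c2cccc(NC(=O)c3ccc(Cl)c(Cl)c3)c2)ccc1O` and its change from compound 3 is 3,4-dichlorophenyl in place of furan-2-yl on a carbonyl carbon. Two measured steps make the same kind of swap in reverse, with furan-2-yl entering in place of a dichlorophenyl group. The modest one is a 4.7-fold lower number from compound 1 to compound 3 (0.67 log units; beyond the scatter) and the large one is a 23-fold lower number from compound 2 to compound 3 (1.37 log units; beyond the scatter) in the same read-out. The placement of the chlorines also counts, with a 5.0-fold higher number from compound 1 to compound 2 (0.70 log units; beyond the scatter) beyond the scatter, and no 3,4-dichlorophenyl compound has a number yet. A higher number than that of compound 3 is therefore expected in this assay with a size in the range of those two steps. The expected move is a 7.9-fold higher number from compound 3 to compound 4 (0.90 log units; beyond the scatter) on this estimate. For compound 4 the estimated value is 6 ug/mL with a range from 2 ug/mL to 18 ug/mL expected.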

Compound 4, half-maximal inhibitory concentration: 25.3 ug/mL
For compound 4 the middle estimate is 4.2-fold (0.62 log units) below the measured one, outside the stated range (above it).
By their numbers in this assay, from the lowest: compound 3; then compound 1; then compounds 2 and 4 (each within the scatter of the next).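

In this assay, 3,4-dichlorophenyl in place of furan-2-yl on this carbonyl carbon gives a 33-fold higher number from compound 3 to compound 4 (1.52 log units; beyond the scatter), so the furan-2-yl compound now has the lowest number against three dichlorophenyl patterns rather than two. Among these compounds, the two patterns without 2,6-substitution are not separated, at a 1.4-fold higher number from compound 2 to compound 4 (0.16 log units; within the scatter), while a 7.1-fold higher number from compound 1 to compound 4 (0.85 log units; beyond the scatter) leaves the 2,6-dichlorophenyl group as the only dichlorophenyl group here clearly closer to furan-2-yl. No measurement at hand explains these differences.

Open, as far as these compounds go, is whether the low number is specific to furan-2-yl or would also appear with thiophen-2-yl, plain phenyl or a phenyl ring carrying a single chlorine. Also open, from the compounds shown here alone, is how a basic amine or a carboxylic acid on this ring would read.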